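Swapping the fluoropyridine for a carboxypyridine in the aryl tail

A few compounds are considered here, and "the series" means these few. Any claim that something is new, unique, unknown or untested is made for them only; others in the source may bear on it.

Three compounds share one core and differ only in the aromatic group attached to the phenyl ring. Compound 1 `CCC(C)(C)Cc1c[nH]c(CCc2ccc(-c3cnccn3)cc2)n1` carries a pyrazin-2-yl and gives 51 nM in an in vitro assay on CHO cells for displacement of a labelled ligand from Bombesin receptor subtype-3 (Homo sapiens), read by scintillation counting, with a stated time of 2 h; on this read-out higher numbers stand for weaker inhibition and lower numbers for stronger inhibition. Compound 2 `CCC(C)(C)Cc1c[nH]c(CCc2ccc(-n3ccnn3)cc2)n1` carries a 1H-1,2,3-triazol-1-yl and gives 390 nM. Compound 3 `CCC(C)(C)Cc1c[nH]c(CCc2ccc(-c3ccc(F)cn3)cc2)n1` carries a 5-fluoropyridin-2-yl and gives 19 nM, the lowest of the three numbers and so the strongest binder among them.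

Compound 4 `CCC(C)(C)Cc1c[nH]c(CCc2ccc(-c3cccnc3C(=O)O)cc2)n1` has not yet been measured. It differs from compound 3 in one place: 2-carboxypyridin-3-yl in place of 5-fluoropyridin-2-yl on an aromatic carbon.

For the measured compounds named here, two measured steps bear on this change, since each replaces the 5-fluoropyridin-2-yl with another aromatic group: a 2.7-fold lower number from compound 1 to compound 3 (0.43 log units; beyond the scatter) and a 21-fold lower number from compound 2 to compound 3 (1.31 log units; beyond the scatter). Both show that moving away from the 5-fluoropyridin-2-yl raised the number, by a modest amount for the pyrazin-2-yl and a large one for the triazole. Going by the values given here, the incoming 2-carboxypyridin-3-yl brings a hydrogen-bond donor that none of the measured groups had, so it is a larger departure than either. The number for compound 4 is therefore expected to rise, a 7.9-fold higher number from compound 3 to compound 4 (0.90 log units; beyond the scatter), with compound 4 estimated at 150 nM (range 30 nM to 800 nM).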

Compound 4, half-maximal inhibitory concentration: 560 nM
Compound 4: the middle estimate sits 3.7-fold (0.57 log units) below what was measured; low and high end bracket the measured number.
By their numbers in this assay, from the lowest: compound 3; then compound 1; then compounds 2 and 4 (each within the scatter of the next).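

Keeping a six-membered aromatic ring with one hetero atom does not by itself keep the number low in this assay: replacing the 5-fluoropyridin-2-yl with the 2-carboxypyridin-3-yl gives a 29-fold higher number from compound 3 to compound 4 (1.47 log units; beyond the scatter) and, against the pyrazin-2-yl, gives an 11-fold higher number from compound 1 to compound 4 (1.04 log units; beyond the scatter) as well. The earlier compounds shown here showed a large loss only with the triazole, whereas this result shows that a pyridine-bearing group on the same aromatic carbon can bind just as poorly, since a 1.4-fold higher number from compound 2 to compound 4 (0.16 log units; within the scatter) leaves those two compounds indistinguishable. Nothing available here measures why the carboxylic acid compound binds so much more weakly, so the result stands without an explanation.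

The 2-carboxypyridin-3-yl differs from the 5-fluoropyridin-2-yl both in its carboxylic acid and in the way its ring is attached, and these compounds cannot separate those two changes. A methyl ester or a primary amide in place of the carboxylic acid, or a plain pyridin-3-yl without it, would show how much of the loss goes with the acid itself.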